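Working notes: methoxy to hydroxy on a shared core

The source may report more compounds than this note shows. Statements on the series, on what has been measured and on what is new or still open speak of the compounds shown alone.

Measured in a functional assay on SW-620 cells (Homo sapiens) for cytotoxicity, read by sulforhodamine B assay, with a stated time of 48 h, tested at 0.01 uM; a higher number here means a weaker effect of the compound at the concentration tested, a lower number a stronger effect:
compound 1 `COc1cc(C)cc(-c2nn(CC#N)cc2-c2ccc(-c3cccc(C(C)=O)c3)nc2)c1` — 91%
compound 2 `Cc1cc(O)cc(-c2nn(CC#N)cc2-c2ccnc(-c3ccc(Oc4ccccc4)cc3)c2)c1` — 88%
compound 3 `COc1cc(C)cc(-c2nn(CC#N)cc2-c2ccnc(-c3ccc(N(C)C)cc3)c2)c1` — 90%

All three numbers sit close together. Compound 3 stands second highest of the three; its nearest neighbour is compound 1, whose number is within the scatter of it, and its furthest is compound 2, whose number is also within the scatter. Among the measured compounds shown here, no compound can be called weaker or stronger than another on these data.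

The next compound, compound 4 `Cc1cc(O)cc(-c2nn(CC#N)cc2-c2ccnc(-c3ccc(N(C)C)cc3)c2)c1`, differs from compound 3 in one place: hydrogen in place of methyl on an oxygen on an aromatic ring. Compound 2 already carries the 3-hydroxy-5-methylphenyl group, with a different group at the other end, and in this assay compound 2 gives 88%, within the scatter of compound 3. A step from compound 3 to compound 4 of a number 1 percentage points lower from compound 3 to compound 4 (within the scatter) is therefore expected, that is, none beyond the scatter. For compound 4 a read-out of 89% is estimated, in the range 80% to 97%.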

Compound 4, a percentage reported as activity, at one concentration (the size of the read-out at that concentration, not a potency): 90%
Estimate against measurement, compound 4: 1 percentage points below; the measured number falls inside the stated range.
By their numbers in this assay, from the lowest: compounds 2, 3, 4 and 1 (each within the scatter of the next).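

In this assay, among the compounds shown here, the pair that differs only at this oxygen gives no change at the digits printed from compound 3 to compound 4 (within the scatter), so the change from methoxy to hydroxy on this aromatic ring leaves no step that can be read at the concentration tested. With the 3-hydroxy-5-methylphenyl group held constant, the other end also gives no step beyond the scatter, with a number 2 percentage points higher from compound 2 to compound 4 (within the scatter) for dimethylamino in place of phenoxy on an aromatic carbon. Nothing available bears on the reason for either of these results.

Still open, as far as these compounds go, is whether a longer chain on this oxygen, such as ethoxy or benzyloxy, or an amine in place of the hydroxy, would give a step beyond the scatter. Also open, from the compounds shown here alone, is whether methoxy and hydroxy would still read alike at a higher concentration.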